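This account rests on a few compounds, and the source may have more. Where it says the series, first, only, none or still open, it means among the compounds named here.

Of the compounds shown here, three that share one core have been measured in a functional assay (aorta) with Oryctolagus cuniculus as the target; on this read-out lower numbers stand for tighter binding and higher numbers for weaker binding. Compound 1 `CCc1nc2c(C)ccnc2n1Cc1ccc(-c2ccccc2C(=O)O)cc1`, which carries ethyl, gives 1.26 nM. Compound 2 `Cc1ccnc2c1nc(C(C)C)n2Cc1ccc(-c2ccccc2C(=O)O)cc1`, which carries isopropyl at the same place, gives 31.6 nM. Compound 3 `CCCCc1nc2c(C)ccnc2n1Cc1ccc(-c2ccccc2C(=O)O)cc1`, which carries butyl there, gives 7.94 nM, the second highest of the three numbers, so it sits in the middle of this small set.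

Compound 4 `Cc1ccnc2c1nc(C1CCC1)n2Cc1ccc(-c2ccccc2C(=O)O)cc1` has not been measured. It differs from compound 3 in one place, with cyclobutyl in place of butyl on an aromatic carbon.

Within the data shown here, three measured steps bear on this change. Replacing ethyl with isopropyl is a large step, a 25-fold higher number from compound 1 to compound 2 (1.40 log units; beyond the scatter). Lengthening ethyl to butyl is a modest one, a 6.3-fold higher number from compound 1 to compound 3 (0.80 log units; beyond the scatter). Exchanging isopropyl for butyl is also modest, a 4.0-fold lower number from compound 2 to compound 3 (0.60 log units; beyond the scatter).

Among the measured compounds shown here, no measured compound has a ring at this place, so any comparison is indirect. Cyclobutyl forks at its first carbon, as the isopropyl of compound 2 does at 31.6 nM, whereas butyl does not. A modest rise is therefore expected in this assay, with the estimated change being a 2.5-fold higher number from compound 3 to compound 4 (0.40 log units; beyond the scatter). For compound 4 the estimated value is 20 nM, with an expected range from 6 nM to 60 nM.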

Compound 4, dissociation constant: 5.01 nM
Compound 4: middle estimate off by 4.0-fold (0.60 log units), on the high side, outside the stated range (below it).
By their numbers in this assay, from the lowest: compound 1; then compounds 4 and 3 (each within the scatter of the next); then compound 2.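

In this assay, closing the chain into a ring changes little at this place: cyclobutyl in place of butyl gives a step within the scatter (a 1.6-fold lower number from compound 3 to compound 4 (0.20 log units; within the scatter)), so compound 3 and compound 4 cannot be told apart. Cyclobutyl forks at its first carbon as isopropyl does, yet the two groups are clearly separated (a 6.3-fold lower number from compound 2 to compound 4 (0.80 log units; beyond the scatter)), so among these compounds a fork at that carbon does not by itself bring the number up to that of compound 2. Ethyl still gives the lowest number of the four, and the ring does not match it (a 4.0-fold higher number from compound 1 to compound 4 (0.60 log units; beyond the scatter)), which leaves compound 1 clearly ahead of compound 4.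

Nothing shown here explains why a four-carbon ring and a four-carbon chain land so close together.

As far as these compounds go, it remains open whether a cyclopropyl or cyclopentyl ring, or a propyl chain, would fall nearer to ethyl or to cyclobutyl, and so whether the size of the group or its shape tracks the number more closely.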